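The compounds below may be only part of what the source reports. "The series", "measured", "known", "first", "only" and "open" are said of these compounds alone.

Of the compounds shown here, two built on one shared core have been measured in a functional assay on cells (Homo sapiens) for cytotoxicity, read by propidium iodide staining, with a stated time of 4 days; a lower number here means a stronger inhibitor, a higher number a weaker inhibitor. Compound 1 `CNC1=CC(=O)c2c(cnc(C)c2C)C1=O` gives 28200 nM. Compound 2 `CNC1=CC(=O)c2cc(C)ncc2C1=O`, which carries hydrogen in place of methyl on an aromatic carbon, gives 10300 nM, a step of a 2.7-fold lower number from compound 1 to compound 2 (0.44 log units; beyond the scatter). Among the two numbers so far, compound 2 stands lowest, with compound 1 as its only neighbour.

Compound 3 `Cc1cc2c(cn1)C(=O)C(NCl)=CC2=O` has not yet been measured. Its change from compound 2 is chloro in place of methyl on an amine nitrogen. Among the measured compounds shown here, the one measured step concerns a methyl on an aromatic carbon, not the amine nitrogen, so no step in hand bears on this change, and the only guide is that both measured numbers sit in the same broad region. With nothing pointing in either direction, compound 3 is expected to give about 10000 nM, within a range of 3000 nM to 35000 nM, a step of a 1.0-fold lower number from compound 2 to compound 3 (0.01 log units; within the scatter) that is expected to stay within the scatter.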

Compound 3, half-maximal inhibitory concentration: 1380 nM
For compound 3 the middle estimate is 7.2-fold (0.86 log units) above the measured one, and the stated range ends above it.
By their numbers in this assay, from the lowest: compound 3; then compound 2; then compound 1.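

The amine nitrogen proves to be a sensitive position in this assay: chloro in place of methyl there gives a 7.5-fold lower number from compound 2 to compound 3 (0.87 log units; beyond the scatter) and puts compound 3 at the low end of the three numbers. Among the compounds shown here, the earlier step concerned only a methyl on an aromatic carbon, so this is the first sign that the group on the amine nitrogen matters, even though one heavy atom simply replaces another. Nothing measured here explains why the number falls.

With only methyl and chloro shown on that nitrogen, it remains open whether other groups there, such as fluoro, bromo, ethyl or a plain hydrogen, would also lower the number. From the compounds shown here alone, it is also open whether the same swap would act alike on the core of compound 1, with its extra methyl.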